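Ether series: no measurable inhibition so far

The source may hold more compounds than are shown below. What is called first, only, known or untested is meant among the compounds shown, and "the series" means these compounds.

Compound 1 `CCO[C@H]1CC=C2CCN(C)[C@H]2C1`; compound 2 `CN1CCC2=CC[C@H](OCc3ccccc3)C[C@@H]21`.

In an assay on HEK293 cells for antagonist activity at Nicotinic acetylcholine receptor alpha-4/beta-2 (Mus musculus), read by FLIPR, using a membrane potential dye (on this read-out higher numbers stand for weaker inhibition and lower numbers for stronger inhibition), compound 1 gives only a limit, > 300000 nM. Compound 2 likewise gives only a limit in this assay, > 300000 nM. The step that the two limits leave unreadable from compound 1 to compound 2 is therefore unreadable, since (the limit of > 300000 nM in this assay, at which 2 of the 2 values shown sit). Compound 3 `COCCO[C@H]1CC=C2CCN(C)[C@H]2C1` carries methoxymethyl in place of phenyl on a saturated chain carbon bound to an oxygen on a saturated carbon. For the measured compounds named here, no measured step reports a number, so no direction can be read; the expectation for compound 3 is simply that it stays at or past the same limit, with an estimated step that the limit leaves unreadable from compound 2 to compound 3. Compound 3 is thus expected at 500000 nM, in the range 100000 nM to 3000000 nM.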

Compound 3, half-maximal inhibitory concentration: > 300000 nM
Compound 3: only a limit was reported; the forecaster's own chance of this, stated with the estimate: 85%; the middle value is on the limit's open side.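

In this assay no step among compound 1, compound 2 and compound 3 can be read, since all three give only a limit: the limit of > 300000 nM in this assay, at which 3 of the 3 values shown sit.

The compounds shown leave open whether any ether on the shared core gives a measurable inhibition.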